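Carboxy in Place of Diethylamino on the Amide Side Chain

This account rests on a few compounds, and the source may have more. Where it says the series, first, only, none or still open, it means among the compounds named here.

Compound 1 `CCn1c(C(=O)NCCC(=O)OC)ccc1C(CC)(CC)c1ccc(OCS(=O)(=O)c2ccccc2)c(C)c1` sits at the assay limit, > 50000 nM, in a functional assay on BXPC-3 cells (Homo sapiens) for antiproliferative activity, read by MTT assay, with a stated time of 24 h; on this read-out lower numbers stand for stronger inhibition and higher numbers for weaker inhibition.
Compound 2 `CCN(CC)CCNC(=O)c1ccc(C(CC)(CC)c2ccc(OCS(=O)(=O)c3ccccc3)c(C)c2)n1CC` gives 6270 nM in this assay.
Compound 3 `CCn1c(C(=O)N[C@@H](CO)CCO)ccc1C(CC)(CC)c1ccc(OCS(=O)(=O)c2ccccc2)c(C)c1` sits at the assay limit, > 50000 nM, in this assay.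

Going by the values given here, compound 2 holds the only number among the three values; the other two rest at the limit (the limit of > 50000 nM in this assay, at which 2 of the 3 values shown sit). Compound 4 `CCn1c(C(=O)NCCC(=O)O)ccc1C(CC)(CC)c1ccc(OCS(=O)(=O)c2ccccc2)c(C)c1` differs from compound 2 by carboxy in place of diethylamino on a saturated chain carbon, two bonds along the chain from an amide-type nitrogen. The step that bears on this is an at least 7.9-fold lower number from compound 1 to compound 2 (0.90 log units; beyond the scatter), where the diethylamino entered and the number fell from the limit. Compound 4 removes that diethylamino again and carries carboxy instead, so a reversal toward weaker inhibition, beyond the scatter, is expected, an 8.0-fold higher number from compound 2 to compound 4 (0.90 log units; beyond the scatter). Compound 4 is therefore estimated at 50000 nM, with a range from 15000 nM to 200000 nM, and a fair chance that only a limit is reported.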

Compound 4, half-maximal inhibitory concentration: > 50000 nM
Compound 4: only a limit was reported; the forecaster's own chance of this, stated with the estimate: 70%; the middle value lies on the limit itself.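

Carboxy in place of diethylamino on a saturated chain carbon, two bonds along the chain from an amide-type nitrogen, gives an at least 7.9-fold higher number from compound 2 to compound 4 (0.90 log units; beyond the scatter) in this assay. Compound 4 gives > 50000 nM, which is a limit, and the steps linking it to compound 1 and compound 3 cannot be read, as those values are limits too. Of the four side chains, only the 2-(diethylamino)ethyl of compound 2 gives a number: the limit of > 50000 nM in this assay, at which 3 of the 4 values shown sit.

Going by these compounds, how far compound 1, compound 3 and compound 4 lie beyond the limit stays open. So does whether another amine, such as dimethylamino, or a longer chain carrying diethylamino would match the number of compound 2.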